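Anilino variation on the shared core: expectation for compound 3

The compounds below may be only part of what the source reports. "The series", "measured", "known", "first", "only" and "open" are said of these compounds alone.

Measured so far, in a functional assay on ECa-109 cells (Homo sapiens) for inhibition, read by MTT assay, with a stated time of 72 h; a lower number here means a stronger inhibitor, a higher number a weaker inhibitor:
- compound 1 `COc1ccc(Nc2nc(SCc3cn(Cc4ccccc4Cl)nn3)nc(-c3ccccc3)c2C#N)cc1`: 7960 nM
- compound 2 `Cc1cccc(Nc2nc(SCc3cn(Cc4ccccc4Cl)nn3)nc(-c3ccccc3)c2C#N)c1`: 15600 nM

Compound 1 stands at the lowest of the two numbers; its nearest neighbour is compound 2, and the step of a 2.0-fold higher number from compound 1 to compound 2 (0.29 log units; within the scatter) is within the scatter, so the two cannot be ordered. Compound 3 `N#Cc1c(Nc2ccccc2F)nc(SCc2cn(Cc3ccccc3Cl)nn2)nc1-c1ccccc1` differs from compound 1 in one place: 2-fluorophenyl in place of 4-methoxyphenyl on a nitrogen on an aromatic ring. Among the measured compounds shown here, the only measured step that bears on it is a 2.0-fold higher number from compound 1 to compound 2 (0.29 log units; within the scatter), which also exchanges the group on the nitrogen on the aromatic ring and stayed within the scatter. For the measured compounds named here, no measured pair replaces 4-methoxyphenyl with 2-fluorophenyl, so nothing supports a step beyond the scatter in either direction. Compound 3 is expected to sit close to its parent, the estimated step being a 1.3-fold higher number from compound 1 to compound 3 (0.10 log units; within the scatter). The estimate for compound 3 is 10000 nM, within 3000 nM to 30000 nM.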

Compound 3, half-maximal inhibitory concentration: 23000 nM
Estimate against measurement, compound 3: 2.3-fold (0.36 log units) below; the measured number falls inside the stated range.
By their numbers in this assay, from the lowest: compounds 1, 2 and 3 (each within the scatter of the next, the first and the last beyond it).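

In this assay, among the compounds shown here, the step of a 2.9-fold higher number from compound 1 to compound 3 (0.46 log units; beyond the scatter) is the first exchange at the nitrogen on the aromatic ring to exceed the scatter, so this position does respond to a change of aryl group, if only modestly. The step of a 1.5-fold higher number from compound 2 to compound 3 (0.17 log units; within the scatter) leaves 3-methylphenyl and 2-fluorophenyl unordered, so only the 4-methoxyphenyl and 2-fluorophenyl pair can be told apart. Nothing available accounts for the difference between those two groups.

The compounds shown leave open whether an aromatic ring is needed on this nitrogen at all, which a cyclohexyl or morpholine group in its place would test, and what an amine or a carboxylic acid on that ring would do. Kind of substituent and its place on the ring also remain unseparated, since all three groups differ in both at once.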